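Removing a fluoro from compound 3: expected stability of compound 4

This account rests on a few compounds, and the source may have more. Where it says the series, first, only, none or still open, it means among the compounds named here.

Compound 3 `O=C(Nc1ccc(F)c(-c2nc3ncc(-c4ccc(F)c(F)c4)cc3[nH]2)c1)N1CCCC1` gives 0.282 h in an ADME assay on microsomes from liver (Homo sapiens) for metabolic stability, read by LC-MS (a higher number here means that the compound lasts longer, a lower number that the compound disappears faster), and that number lies within the usual scatter of compound 1 `O=C(Nc1ccc(F)c(-c2nc3ncc(-c4cccc(F)c4)cc3[nH]2)c1)N1CCCC1` with 0.185 h and of compound 2 `O=C(Nc1ccc(F)c(-c2nc3ncc(-c4cc(F)cc(F)c4)cc3[nH]2)c1)N1CCCC1` with 0.175 h. Compound 4 `O=C(Nc1ccc(F)c(-c2nc3ncc(-c4ccc(F)cc4)cc3[nH]2)c1)N1CCCC1` differs from compound 3 by hydrogen in place of fluoro on an aromatic carbon. The measured steps that bear on this are a 1.5-fold higher number from compound 1 to compound 3 (0.18 log units; within the scatter) and a 1.1-fold lower number from compound 1 to compound 2 (0.02 log units; within the scatter), both within the scatter, so adding or removing a fluoro on this ring has not moved the number beyond the scatter among these three compounds. Compound 4 is therefore expected to show a 1.3-fold lower number from compound 3 to compound 4 (0.11 log units; within the scatter), and its estimated half-life is 0.22 h, with a range from 0.12 h to 0.4 h.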

Compound 4, half-life: 0.203 h
Estimate against measurement, compound 4: 1.1-fold (0.03 log units) above; the range from low to high includes it.
By their numbers in this assay, from the lowest: compounds 2, 1, 4 and 3 (each within the scatter of the next).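

In this assay, removing the fluoro from the 3,4-difluorophenyl group leaves the number within the scatter: a 1.4-fold lower number from compound 3 to compound 4 (0.14 log units; within the scatter). The 4-fluorophenyl group also stays within the scatter of the other two patterns, with a 1.2-fold higher number from compound 2 to compound 4 (0.06 log units; within the scatter) and a 1.1-fold higher number from compound 1 to compound 4 (0.04 log units; within the scatter), so all four fluoro patterns at this position lie within the scatter of one another. Adding the fluoro gives a comparable result in two settings: the same change on two cores in this assay, a 1.1-fold lower number (0.02 log units; within the scatter) from compound 1 to compound 2 and a 1.4-fold higher number (0.14 log units; within the scatter) from compound 4 to compound 3, 1.5-fold (0.17 log units) apart, within the scatter of two such steps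

Going by these compounds, these compounds carry only fluoro or hydrogen on this ring, so it stays open whether an amine, a methoxy group or a carboxylic acid there would move the half-life beyond the scatter. On these data alone, the effect of changes elsewhere on the shared core also stays open.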